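The compounds below may be only part of what the source reports. "The series", "measured", "known", "first", "only" and "open" are said of these compounds alone.

Compound 2 `COC(=O)[C@@]1(C)CCC=C2[C@@H]1CC[C@@H](C)[C@]2(C)Cc1c[nH]c2c(Br)cccc12` gives 24000 nM in a functional assay on T47D cells (Homo sapiens) for inhibition, read by sulforhodamine B assay, with a stated time of 48 h (a lower number here means a stronger inhibitor of growth, a higher number a weaker inhibitor of growth), the higher of the two numbers in hand. Compound 1 `COC(=O)[C@@]1(C)CCC=C2[C@@H]1CC[C@@H](C)[C@]2(C)Cc1c[nH]c2ccccc12`, the parent with hydrogen at the same aromatic carbon, gives 4200 nM in this assay. Among the measured compounds shown here, the only measured step, a 5.7-fold higher number from compound 1 to compound 2 (0.76 log units; beyond the scatter), shows that putting bromo in place of hydrogen at that carbon raises the number beyond the scatter. Compound 3 `COC(=O)[C@@]1(C)CCC=C2[C@@H]1CC[C@@H](C)[C@]2(C)Cc1c[nH]c2c(Cl)cccc12` is the next member: chloro in place of bromo on an aromatic carbon. For the measured compounds named here, no measured pair sets chloro against bromo, so the step from compound 1 to compound 2 is the only guide, and a chloro group is expected to give a number lying between those seen with hydrogen and with bromo. For compound 3 the step expected in this assay is therefore a 1.7-fold lower number from compound 2 to compound 3 (0.23 log units; within the scatter). Its number would thus be expected to stay above that of compound 1 and close to that of compound 2. For compound 3 the estimate in this assay is 14000 nM, with a range from 5000 nM to 40000 nM.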

Compound 3, concentration for 50% growth inhibition: 24000 nM
The estimate for compound 3 lay 1.7-fold (0.23 log units) below the measured number, within the range that was stated.
By their numbers in this assay, from the lowest: compound 1; then compounds 2 and 3 (each within the scatter of the next).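

In this assay, the change from bromo to chloro gives no change at the digits printed from compound 2 to compound 3 (within the scatter), so the two halogens cannot be told apart on this aromatic carbon of the six-membered aromatic ring of carbon only. Chloro in place of hydrogen gives a 5.7-fold higher number from compound 1 to compound 3 (0.76 log units; beyond the scatter) and matches the step seen with bromo, a 5.7-fold higher number from compound 1 to compound 2 (0.76 log units; beyond the scatter), so the weaker growth inhibition relative to compound 1 is not confined to compound 2 and is shared by both halogen compounds. Nothing measured on these compounds bears on the origin of this shared step.

Still open, as far as these compounds go, is whether fluoro, methoxy or an amine at this carbon would also give a number beyond the scatter of that of compound 1. Also open, from the compounds shown here alone, is whether chloro on another aromatic carbon of the same ring would give a step of similar size.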